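Trading an acetoxybutyl chain for an oxanyl carbonyl group

The compounds below may be only part of what the source reports. "The series", "measured", "known", "first", "only" and "open" are said of these compounds alone.

Of the compounds shown here, two of a shared core have been measured in a functional assay on HeLa cells (Homo sapiens) for cytotoxicity, read by MTT assay; a higher number here means a weaker inhibitor, a lower number a stronger inhibitor. Compound 1 `CC(=O)OCCO[C@H](CC=C(C)C)C1=CC(=O)c2c(O)ccc(O)c2C1=O` gives 41500 nM in this assay, and compound 2 `CCC(CO[C@H](CC=C(C)C)C1=CC(=O)c2c(O)ccc(O)c2C1=O)OC(C)=O` gives 44000 nM. Compound 2 thus holds the higher of the two numbers, but the gap to compound 1, a 1.1-fold higher number from compound 1 to compound 2 (0.03 log units; within the scatter), lies within the scatter, so the two cannot be ordered.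

The next compound, compound 3 `CC(C)=CC[C@@H](OC(=O)C1CCCOC1)C1=CC(=O)c2c(O)ccc(O)c2C1=O`, departs from compound 2 by (oxan-3-yl)carbonyl in place of 2-acetoxybutyl on an oxygen on a saturated carbon. Cut one bond further out, the same difference reads 2-acetoxybutoxy to ((oxan-3-yl)carbonyl)oxy, so the oxygen on the saturated carbon now carries a carbonyl rather than a chain carbon. Within the data shown here, the only measured step, a 1.1-fold higher number from compound 1 to compound 2 (0.03 log units; within the scatter), changed the 2-acetoxybutyl group itself by an ethyl in place of hydrogen and left the number where it was; no measured step touches the kind of attachment at that oxygen. On this evidence a step of a 1.1-fold lower number from compound 2 to compound 3 (0.04 log units; within the scatter) is expected, with little reason to foresee movement beyond the scatter. Compound 3 is therefore estimated at 40000 nM in this assay, within a range of 12000 nM to 130000 nM.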

Compound 3, half-maximal inhibitory concentration: 60500 nM
The estimate for compound 3 lay 1.5-fold (0.18 log units) below the measured number; low and high end bracket the measured number.
By their numbers in this assay, from the lowest: compounds 1, 2 and 3 (each within the scatter of the next).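

Among these compounds, this is the first measured change in the kind of attachment at the oxygen on a saturated carbon, with a carbonyl in place of a chain carbon and a six-membered non-aromatic ring entering with it, and it gives a 1.4-fold higher number from compound 2 to compound 3 (0.14 log units; within the scatter). Set against the shorter chain, the same kind of exchange gives a 1.5-fold higher number from compound 1 to compound 3 (0.16 log units; within the scatter), so in this assay the 2-acetoxyethyl, 2-acetoxybutyl and (oxan-3-yl)carbonyl groups cannot be told apart, and at this position the switch from a chain ether to a ring-bearing ester has no readable effect on the number. No accompanying measurement bears on this result.

The compounds shown leave open whether any group on this oxygen can move the number beyond the scatter, as a benzoyl group, a 2-aminoethyl chain or a longer chain ending in a carboxylic acid might test. They also leave the carbonyl link and the ring unseparated, since compound 3 differs from compound 2 in both at once, and an open-chain hexanoyl group would pull the two apart.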